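Imine aryl variation on the shared core: compound 4

The source may report more compounds than this note shows. Statements on the series, on what has been measured and on what is new or still open speak of the compounds shown alone.

Of the compounds shown here, three have been tested in a functional assay on MCF7 cells (Homo sapiens) for cytotoxicity, read by sulforhodamine B assay, with a stated time of 48 h; on this read-out higher numbers stand for weaker inhibition and lower numbers for stronger inhibition. Compound 1 `COc1ccc(C2C(C#N)=C(N)Oc3nc(Nc4ccc(S(N)(=O)=O)cc4)sc32)cc1` carries a free amino group on the double-bonded ring carbon and gives 27500 nM. Compound 2 `COc1ccc(C2C(C#N)=C(/N=C/c3cccc(Br)c3)Oc3nc(Nc4ccc(S(N)(=O)=O)cc4)sc32)cc1` gives 9390 nM, and compound 3 `COc1ccc(C2C(C#N)=C(/N=C/c3ccc(Cl)cc3Cl)Oc3nc(Nc4ccc(S(N)(=O)=O)cc4)sc32)cc1` gives 23500 nM. On these numbers compound 3 stands second highest of three; its nearest neighbour is compound 1, with the gap within the scatter, and its furthest is compound 2, the step of a 2.5-fold higher number from compound 2 to compound 3 (0.40 log units; beyond the scatter) being beyond the scatter but modest.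

Compound 4 `COc1ccc(C2C(C#N)=C(/N=C/c3ccc([N+](=O)[O-])cc3)Oc3nc(Nc4ccc(S(N)(=O)=O)cc4)sc32)cc1` is not yet measured. It differs from compound 3 in one place: 4-nitrophenyl in place of 2,4-dichlorophenyl on a carbon with a double bond to nitrogen. The step that bears most directly on this is the other swap of the aryl on the imine carbon, a 2.5-fold higher number from compound 2 to compound 3 (0.40 log units; beyond the scatter). The steps from the free amine, a 2.9-fold lower number from compound 1 to compound 2 (0.47 log units; beyond the scatter) and a 1.2-fold lower number from compound 1 to compound 3 (0.07 log units; within the scatter), show that the whole imine-aryl appendage moves the number only modestly or not at all. A change of similar size, in either direction, is therefore expected here, most likely a small shift toward a lower number. In this assay compound 4 is estimated at 15000 nM, within 6000 nM to 40000 nM, which means an expected step of a 1.6-fold lower number from compound 3 to compound 4 (0.19 log units; within the scatter).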

Compound 4, half-maximal inhibitory concentration: 9700 nM
Compound 4: the middle estimate sits 1.5-fold (0.19 log units) above what was measured; the measured number falls inside the stated range.
By their numbers in this assay, from the lowest: compounds 2 and 4 (each within the scatter of the next); then compounds 3 and 1 (each within the scatter of the next).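

In this assay, 4-nitrophenyl on the carbon with a double bond to nitrogen gives a 2.4-fold lower number from compound 3 to compound 4 (0.38 log units; beyond the scatter) in place of 2,4-dichlorophenyl, a modest step of about the same size as the opposite one, a 2.5-fold higher number from compound 2 to compound 3 (0.40 log units; beyond the scatter) and so 2,4-dichlorophenyl is now the aryl group set apart from two others rather than from one. The step of a 1.0-fold higher number from compound 2 to compound 4 (0.01 log units; within the scatter) shows that 3-bromophenyl and 4-nitrophenyl cannot be told apart here, even though the two groups share only the aromatic ring itself. With a 2.8-fold lower number from compound 1 to compound 4 (0.45 log units; beyond the scatter) as well, two of the three aryl imines now have numbers modestly lower than the free amine, while compound 3 goes against this, so the imine appendage alone does not set the number and the aryl group on it matters within a narrow range.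

Still open, as far as these compounds go, is whether an unsubstituted phenyl, a single chlorine on the phenyl, or a pyridine ring in this place would group with compound 2 and compound 4 or with compound 3. Nothing at hand bears on why 2,4-dichlorophenyl stands apart from the other two aryl groups.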